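Phenyl for methoxy in an inactive styrene series

A few compounds are considered here, and "the series" means these few. Any claim that something is new, unique, unknown or untested is made for them only; others in the source may bear on it.

Compound 1, `C=C[C@@](C)(/C=C/c1ccc(OC)cc1)CCC=C(C)C`, in a functional assay on NALM-6 cells (Homo sapiens) for cytotoxicity, with a stated time of 72 h (a higher number here means that more compound is needed for the effect, a lower number that less compound is needed), gives > 43400 nM, which is a limit of the assay and not a number.
Compound 2, `C=C[C@@](C)(/C=C/c1ccc(O)cc1)CCC=O`, in this assay gives > 43400 nM, also a limit of the assay.
Compound 3, `C=C[C@@](C)(/C=C/c1ccc(O)cc1)CC/C=C/C(=O)c1ccccc1`, in this assay gives > 43400 nM, again a limit of the assay.

Compound 1 therefore stands where every measured compound stands: at the limit of > 43400 nM in this assay, at which 3 of the 3 values shown sit. Among the compounds with values here, no compound among the three gives a measured number, so no step between two measured values exists, and nothing separates compound 1 from compound 2 or compound 3 beyond the fact that all three reach the same limit.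

Compound 4, `C=C[C@@](C)(/C=C/c1ccc(-c2ccccc2)cc1)CCC=C(C)C`, differs from compound 1 in one place: phenyl in place of methoxy on an aromatic carbon. The methoxy leaves, a phenyl enters, and the rest of the shared core is unchanged.

Because compound 1 sits at the limit of > 43400 nM in this assay, at which 3 of the 3 values shown sit, alongside both other measured compounds, no shift in this assay beyond the usual scatter is expected for compound 4, and the step that the limit leaves unreadable from compound 1 to compound 4 is estimated to be essentially none. Compound 4 is expected to give about 60000 nM, within a range from 20000 nM to 200000 nM, most likely reported again as a limit.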

Compound 4, half-maximal effective concentration: > 43400 nM
Compound 4: a limit, no number; the forecaster's own chance of this, stated with the estimate: 85%; the middle value is on the limit's open side.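

Compound 1 and compound 4 both give a limit of the assay and not a number, so no step between them can be read: the limit of > 43400 nM in this assay, at which 4 of the 4 values shown sit.

The compounds shown leave open which change to the shared core, if any, would give a measured number in this assay.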